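The source may hold more compounds than are shown below. What is called first, only, known or untested is meant among the compounds shown, and "the series" means these compounds.

Compound 3 `O=C(OCOCN1c2ccccc2C(=O)N(Cc2ccccc2)S1(=O)=O)c1ccccc1` gives the lowest of the two plain numbers in a functional assay on HEL cells (Homo sapiens) for inhibition (on this read-out higher numbers stand for lower toxicity in this test and lower numbers for higher toxicity in this test), where compound 3 gives 37000 nM. Its nearest neighbour on that scale is compound 1 `O=C1c2ccccc2N(Cc2ccccc2Cl)S(=O)(=O)N1Cc1ccccc1`, which in this assay gives 88000 nM, a gap beyond the scatter. Compound 2 `O=C1c2ccccc2N(Cc2cccc(Cl)c2)S(=O)(=O)N1Cc1ccccc1` reaches only a limit of the test rather than a number, since in this assay compound 2 gives > 200000 nM (the limit of > 200000 nM in this assay, at which 1 of the 3 values shown sits). Compound 4 `C#CCOCN1c2ccccc2C(=O)N(Cc2ccccc2)S1(=O)=O` is the compound still to be measured, and it differs from compound 3 in one place: ethynyl in place of benzoyloxy on a saturated chain carbon bound to an oxygen on a saturated carbon. For the measured compounds named here, the only measured step, an at least 2.2-fold higher number from compound 1 to compound 2 (0.35 log units; beyond the scatter), concerns a chlorophenyl group at a different place in the shared core, so it says nothing directly about swapping benzoyloxy for ethynyl. Going by the values given here, with no step of this kind to lean on, the direction is open; the change removes the larger group, and the expectation leans towards a somewhat higher number, within a wide range. Compound 4 is therefore expected to give 70000 nM in this assay, between 20000 nM and 200000 nM, an expected step of a 1.9-fold higher number from compound 3 to compound 4 (0.28 log units; within the scatter).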

Compound 4, half-maximal cytotoxic concentration: > 140000 nM
Compound 4: a limit, no number (the forecaster's own chance of this, stated with the estimate: 25%); middle value at least 2.0-fold (0.30 log units) away from the limit.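

Compound 4 stops at a limit of this assay rather than at a number. For the compounds shown here, putting ethynyl in place of benzoyloxy on this saturated chain carbon gives an at least 3.7-fold higher number from compound 3 to compound 4 (0.57 log units; beyond the scatter), so this is the first sign that the group at this place can move the read-out towards lower toxicity in this test, which the chlorophenyl step could not show. The comparison with the chlorinated compounds adds little: the other readable step is an at least 1.5-fold higher number from compound 1 to compound 4 (0.20 log units; that floor lies within the scatter), and the step involving compound 2 cannot be read, since both of its values are limits.

As far as these compounds go, the true size of the change stays open, as does whether losing the benzoyloxy group or gaining the ethynyl group matters more. From the compounds shown here alone, how an amine, a carboxylic acid or a longer chain would read at this place also remains unknown.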